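Swapping an aminophenyl arm for a hydroxyethyl chain

The source may report more compounds than this note shows. Statements on the series, on what has been measured and on what is new or still open speak of the compounds shown alone.

Four compounds share one core and are judged in a functional assay on HCT-116 cells (Homo sapiens) for cytotoxicity, read by MTT assay, with a stated time of 72 h; a higher number here means a weaker inhibitor, a lower number a stronger inhibitor. Compound 1 `C[C@@H](CO)Nc1nc(C(=O)NCc2ccc(F)cc2)c(O)c2ncccc12` gives "not determined" (no result reported), that is, no reported result. Compound 2 `Nc1ccc(Nc2c(C(=O)NCc3ccc(F)cc3)nc(Br)c3cccnc23)cc1` gives 7000 nM, and compound 3 `CS(=O)(=O)NCCCN(c1nc(C(=O)NCc2ccc(F)cc2)c(O)c2ncccc12)S(C)(=O)=O` gives 7000 nM; these two sit level within the usual scatter, so neither can be called the stronger. Compound 4 `O=C(NCc1ccc(F)cc1)c1nc(Br)c2cccnc2c1NCCO` has not yet been tested. It differs from compound 2 in one place: 2-hydroxyethyl in place of 4-aminophenyl on a nitrogen on an aromatic ring. Among the compounds with values here, no measured pair shows this kind of exchange, so there is no directly comparable step; a modest loss, or no change beyond the scatter, seems the most likely outcome. The step expected is a 1.4-fold higher number from compound 2 to compound 4 (0.15 log units; within the scatter). Compound 4 is estimated at 10000 nM, within a range from 3000 nM to 35000 nM.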

Compound 4, half-maximal inhibitory concentration: > 20000 nM
Compound 4 gave a limit, no number; the forecaster's own chance of this, stated with the estimate: 15%; middle value at least 2.0-fold (0.30 log units) from the limit.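

Within the data shown here, on a nitrogen on an aromatic ring, putting 2-hydroxyethyl in place of 4-aminophenyl is the first single-place change that can be read here, and in this assay it gives an at least 2.8-fold higher number from compound 2 to compound 4 (0.45 log units; beyond the scatter). The reading for compound 4 is a limit of the assay, not a number, so the full size of this step stays unknown: the limit of > 20000 nM in this assay, at which 1 of the 4 values shown sits.

In this one pair, then, the position does not take the exchange without a loss of strength. The pair changes the ring and its amine together, which leaves open which of the two counts. A plain phenyl group on that nitrogen, with the ring but no amine, is the comparison that would separate them.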